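This account rests on a few compounds, and the source may have more. Where it says the series, first, only, none or still open, it means among the compounds named here.

Measured compounds in an assay on A549 cells with Cystic fibrosis transmembrane conductance regulator variant F508del (Homo sapiens) as the target, read by fluorescence, with a stated time of 25 min; on this read-out lower numbers stand for smaller maximal responses and higher numbers for larger maximal responses:

- compound 1 `COc1ccc(CN2CCc3nc(-c4ccccn4)nc(NCCCn4ccnc4)c3C2)cc1`: "not active" (no number reported)
- compound 2 `COc1ccc(CN2CCc3nc(-c4ccccn4)nc(N4CCN(CC(N)=O)CC4)c3C2)cc1`: 36.8%
- compound 3 `CCN(C(C)=O)C1CCN(c2nc(-c3ccccn3)nc3c2CN(Cc2ccc(OC)cc2)CC3)C1`: "not active" (no number reported)

Compound 3 stands at the bottom of this small set. In this assay compound 3 is recorded as "not active" (no number reported), with no number behind it, and compound 1 sits in the same position with "not active" (no number reported). Only compound 2 carries a number, giving 36.8% in this assay. No step between any two of these compounds is given, so how far compound 3 lies beneath compound 2 cannot be stated; the two results show only that one gave a measurable maximal response and the other did not.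

Compound 4 `CCN(C(C)=O)C1CCN(c2nc(-c3ccccn3)nc3c2CN(Cc2ccc(Cl)cc2)CC3)C1` is the next compound and has not yet been measured. It differs from compound 3 in one place: chloro in place of methoxy on an aromatic carbon. The rest of the molecule, with its shared core and its ring-bearing side groups, is kept.

With no measured step of this kind in the set, the size of any step in this assay from compound 3 to compound 4 is unknown. Given that compound 3 gave "not active" (no number reported), the expectation is a small step at most, with a fair chance that compound 4 again returns no number. The estimated maximal response for compound 4 is 12%, within a range from 0% to 35%.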

Compound 4, largest response reached (Emax), in percent of the reference or control that the assay uses: "not active" (no number reported)
Compound 4 has no reported number here; no gap can be computed for the estimate.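

In this assay, among these compounds, compound 3 gives "not active" (no number reported) and compound 4 gives "not active" (no number reported), so no step between them can be read. No measurement shown offers an explanation for this result. The compounds shown leave open whether chloro in place of methoxy changes the maximal response in a compound that gives a measurable one.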